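From free acid to chlorophenyl amide

The compounds below may be only part of what the source reports. "The series", "measured", "known", "first", "only" and "open" are said of these compounds alone.

In a functional assay on Bel-7402 cells (Homo sapiens) for inhibition, read by MTT assay, with a stated time of 24 h, tested at 0.1 ug/mL (a higher number here means more inhibition of growth at the concentration tested, a lower number less inhibition of growth), compound 1 (`CC(=O)SCCC(CCCCC(=O)O)SC(C)=O`) gives 10.3% at the single concentration tested. Compound 3 (`O=C(CCCCC(S)CCS)Nc1ccc([N+](=O)[O-])cc1`) gives 1.88% in this assay and lies within the usual scatter of compound 1, so the two cannot be told apart. Compound 2 (`O=C(CCCCC1CCSS1)Nc1cccc(C(F)(F)F)c1`) is reported as "not active" (no number reported) with no number attached. Within the data shown here, compound 1 therefore stands level with compound 3 on the only two numbers available.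

Compound 4 (`CC(=O)SCCC(CCCCC(=O)Nc1cccc(Cl)c1)SC(C)=O`) has not yet been measured. It keeps the core of compound 1 and changes in one place, where (3-chlorophenyl)amino takes the place of hydroxy on a carbonyl carbon ((3-chlorophenyl)amino in place of hydroxy on a carbonyl carbon). This turns the free acid into an amide. Among the measured compounds shown here, no measured pair shows this exchange on its own, so any expectation is indirect. Compound 3 also carries an aromatic ring on an amide carbonyl and shows 1.88% in this assay but it differs from compound 4 elsewhere too, which makes it only a loose guide. The expected step of a number 1.3 percentage points lower from compound 1 to compound 4 (within the scatter) stays within the usual scatter, so no real change is anticipated. For compound 4 the estimated value is 9% with an expected range from 0% to 25% in repeated measurements.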

Compound 4, percent growth inhibition at one concentration: 3.72%
Beside the measured number, compound 4's estimate is 5.3 percentage points above it; measured number inside the range.
By their numbers in this assay, from the lowest: compounds 3, 4 and 1 (each within the scatter of the next).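

Among these compounds, putting (3-chlorophenyl)amino in place of hydroxy on a carbonyl carbon gives the first direct comparison at this position, something the earlier compounds could not offer. In this assay the exchange is a number 6.6 percentage points lower from compound 1 to compound 4 (within the scatter), so a free acid and an amide carrying an added aromatic ring cannot be told apart at this single concentration, and this one change shows no measurable effect on growth inhibition here. Nothing measured on these compounds offers an explanation for this result.

A single exchange at one low concentration says little about the position in general, and a step this small may hide a real difference that repeated measurements would be needed to reveal. A plain phenylamino group would test whether the chlorine matters, while a benzylamino group or a methyl ester on the same carbonyl carbon would show whether other replacements for hydroxy leave the reading equally unchanged.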